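Replacing the 4-(trifluoromethyl)pyrimidin-2-yl group of compound 2

This account rests on a few compounds, and the source may have more. Where it says the series, first, only, none or still open, it means among the compounds named here.

Measured compounds:
compound 1, `CC(C)[C@H](NC(=O)COc1cccc2ccccc12)C(=O)N[C@@H](CC(=O)O)C(=O)CSc1nc(-c2ccccc2)cs1`: > 200000 nM
compound 2, `CC(C)[C@H](NC(=O)COc1cccc2ccccc12)C(=O)N[C@@H](CC(=O)O)C(=O)COc1nccc(C(F)(F)F)n1`: > 200000 nM

In a functional assay on Jurkat cells (Homo sapiens) for inhibition (on this read-out lower numbers stand for stronger inhibition and higher numbers for weaker inhibition), compound 2 gives only a limit, > 200000 nM. Compound 1 also reaches only a limit, > 200000 nM. The step that the two limits leave unreadable from compound 1 to compound 2 therefore cannot be read, as the limit of > 200000 nM in this assay, at which 2 of the 2 values shown sit, shows. Compound 3, `CC(C)[C@H](NC(=O)COc1cccc2ccccc12)C(=O)N[C@@H](CC(=O)O)C(=O)COn1nnc2ccccc2c1=O`, differs from compound 2 by a group of 11 heavy atoms (7 carbon, 3 nitrogen, 1 oxygen; one six-membered aromatic ring of carbon only, one six-membered aromatic ring with 3 hetero atoms) in place of a group of 10 heavy atoms (5 carbon, 2 nitrogen, 3 fluorine; one six-membered aromatic ring with 2 hetero atoms), on an oxygen on a saturated carbon. For the measured compounds named here, no measured step gives a readable size for a change of this kind, so in this assay no step beyond the scatter can be foreseen, and compound 3 is expected to stay at the limit as well. The estimate for compound 3 is 200000 nM, between 50000 nM and 1000000 nM. This estimate means an expected step of a number no higher from compound 2 to compound 3 (the limit leaves the size open).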

Compound 3, half-maximal inhibitory concentration: 137000 nM
The estimate for compound 3 lay 1.5-fold (0.16 log units) above the measured number, and the stated range covers the measured number.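

In this assay compound 3 gives 137000 nM, the only readable number at this position among the compounds shown. This gives an at least 1.4-fold lower number from compound 2 to compound 3 (0.16 log units; that floor lies within the scatter) and an at least 1.4-fold lower number from compound 1 to compound 3 (0.16 log units; that floor lies within the scatter), so neither change is shown to go beyond the scatter. Readings here remain constrained by the assay limit: the limit of > 200000 nM in this assay, at which 2 of the 3 values shown sit.

Open, going by these compounds, is whether a simple amine or a longer chain on this oxygen would bring the number far lower. Also open, on these data alone, is whether the group that enters in compound 3 would give a similar number if joined through sulfur instead of oxygen.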